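A few compounds are considered here, and "the series" means these few. Any claim that something is new, unique, unknown or untested is made for them only; others in the source may bear on it.

Measured compounds:
- compound 1, `Cc1cc(CCCCCC(=O)O)ccc1-c1noc(-c2ccc(C3CCCCC3)cc2)n1`: 1080 nM in a functional assay on CHO cells for agonist activity at sphingosine 1-phosphate receptor 5 (Homo sapiens), read by GTPgammaS binding; a lower number here means that less compound is needed, a higher number that more compound is needed for the effect
- compound 2, `CCCCc1ccc(-c2nc(-c3ccc(CCC(=O)O)cc3C)no2)nc1`: > 10000 nM, a limit of this assay
- compound 3, `Cc1cc(CCC(=O)O)ccc1-c1noc(-c2ccc(CC(C)C)cn2)n1`: > 1000 nM, a limit of this assay

Compound 3 stands at a limit in this assay, and one of the other two values shown is a limit as well, so its place among the numbers cannot be fixed. Going by the values given here, compound 1 is the only one with a number. The step that the two limits leave unreadable from compound 2 to compound 3 cannot be read, since both its ends sit at limits (the limit of > 10000 nM in this assay, at which 1 of the 3 values shown sits, and (the limit of > 1000 nM in this assay, at which 1 of the 3 values shown sits)).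

Compound 4, `Cc1cc(CCC(=O)O)ccc1-c1noc(-c2ccc(C(F)(F)C(C)C)cn2)n1`, differs from compound 3 by 1,1-difluoro-2-methylpropyl in place of isobutyl on an aromatic carbon — in words, 1,1-difluoro-2-methylpropyl in place of isobutyl on an aromatic carbon, two atoms from the ring nitrogen and para to a large group. Among the compounds with values here, no measured step bears on this change, and compound 3 itself gives only a limit, so no direction or size can be drawn from the data. Compound 4 is therefore expected to remain in the same region, with the step that the limit leaves unreadable from compound 3 to compound 4 being an assumption of no change beyond the scatter. The estimate for compound 4 in this assay is 3000 nM, with a range from 800 nM to 15000 nM.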

Compound 4, half-maximal effective concentration: 820 nM
Beside the measured number, compound 4's estimate is 3.7-fold (0.56 log units) above it; the range from low to high includes it.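

In this assay, 1,1-difluoro-2-methylpropyl in place of isobutyl on this aromatic carbon, two atoms from the ring nitrogen and para to a large group, gives an at least 1.2-fold lower number from compound 3 to compound 4 (0.08 log units; that floor lies within the scatter), so the change cannot yet be told apart from no change. Only this floor can be read because compound 3 stands at a limit: the limit of > 1000 nM in this assay, at which 1 of the 4 values shown sits.
With butyl as the group replaced, the same place gives an at least 12-fold lower number from compound 2 to compound 4 (1.08 log units; beyond the scatter), the first step at this position that is readable as beyond the scatter, and its floor rests on the limit of compound 2: the limit of > 10000 nM in this assay, at which 1 of the 4 values shown sits.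

Going by these compounds, the step between compound 2 and compound 3 cannot be read, and the true distance between compound 3 and compound 4 stays open. Also open, on these data alone, is what a trifluoromethyl group, or a single fluorine on the chain carbon bound to the ring, would do at this place.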